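Nitro on the furan ring: notes on a small series

The source may hold more compounds than are shown below. What is called first, only, known or untested is meant among the compounds shown, and "the series" means these compounds.

Measured so far in a functional assay on the whole organism (strain Wistar Albino) for inhibition, with Rattus norvegicus as the target, read by paw edema, with a stated time of 4 h, at a dose of 20 mg/kg; on this read-out lower numbers stand for less inhibition and higher numbers for more inhibition at the one dose given (going by the name of the read-out):
compound 1 `COc1ccc(Cl)c(-c2nnc3n2NC(c2ccco2)S3)c1` gives 25.6%
compound 2 `Cc1occc1-c1nnc2n1NC(c1ccco1)S2` gives 25.9%
compound 3 `COc1ccc(Cl)c(-c2nnc3n2NC(c2ccc([N+](=O)[O-])o2)S3)c1` gives 24.2%

Compound 1 and compound 3 differ by nitro in place of hydrogen on an aromatic carbon. The step of a number 1.4 percentage points lower from compound 1 to compound 3 (within the scatter) lies within the scatter, so the two values cannot be told apart. Compound 2 carries a different core; the difference between the two cores is not broken down here, and its value sits within the scatter of both compound 1 and compound 3.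

Compound 4 `Cc1occc1-c1nnc2n1NC(c1ccc([N+](=O)[O-])o1)S2` is not yet measured. It differs from compound 2 by nitro in place of hydrogen on an aromatic carbon. This is the same change as that from compound 1 to compound 3, and it occurs twice among the compounds shown; the place is the same word for word.

For compound 4 the expected step is a number 1.4 percentage points lower from compound 2 to compound 4 (within the scatter), because a number 1.4 percentage points lower from compound 1 to compound 3 (within the scatter) gave no movement beyond the scatter on the other core. In this assay compound 4 is therefore estimated at 24.5%, with a range from 15% to 34%.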

Compound 4, a percentage reported as inhibition, in the whole organism at one dose (the size of the read-out at that dose, not a potency): 24.9%
Compound 4: middle estimate off by 0.4 percentage points, on the low side; low and high end bracket the measured number.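

In this assay the change of nitro in place of hydrogen on an aromatic carbon now reads twice, the new step being a number 1 percentage points lower from compound 2 to compound 4 (within the scatter), and it stands beside the earlier one on the other core: the same change on two cores in this assay, a number 1.4 percentage points lower (within the scatter) from compound 1 to compound 3 and a number 1 percentage points lower (within the scatter) from compound 2 to compound 4, 0.4 percentage points apart, within the scatter of two such steps

On the two cores shown, then, the change carries over in the plain sense that neither step leaves the scatter and the two steps cannot be told apart. Among these compounds, this does not show that the nitro group is without consequence in general, as the comparison rests on only two cores at one dose and one stated time, and a difference between cores smaller than the scatter would go unseen.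

The compounds shown hold only hydrogen or nitro at this place, so it stays open whether an amine or a carboxylic acid on the same aromatic carbon would give a step beyond the scatter. Also open, on these data alone, is whether the four compounds would separate at any other dose.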